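The source may report more compounds than this note shows. Statements on the series, on what has been measured and on what is new or still open speak of the compounds shown alone.

Measured so far in a functional assay on HL-60 cells (Homo sapiens) for inhibition, read by MTT assay, with a stated time of 72 h; a lower number here means a stronger inhibitor, a higher number a weaker inhibitor:
- compound 1 `COc1cc(OC)cc(N2CCN(C(=O)c3oc(C)nc3-c3ccccc3F)CC2)c1`: 10.3 nM
- compound 2 `COc1cc(OC)cc(N2CCN(C(=O)c3oc(C)nc3-c3ccc(F)cc3)CC2)c1`: 38.5 nM
- compound 3 `Cc1nc(-c2cccc(F)c2)c(C(=O)N2CCN(c3cc(Cl)cc(Cl)c3)CC2)o1`: 41.7 nM

In this assay compound 3 lies within the scatter of compound 2, and its number is clearly higher than that of compound 1. The next step leads to compound 4 `COc1cc(OC)cc(N2CCN(C(=O)c3oc(C)nc3-c3cccc(F)c3)CC2)c1`, which carries 3,5-dimethoxyphenyl in place of 3,5-dichlorophenyl on an amine nitrogen in a ring. Among the compounds with values here, no measured step makes this exchange directly. Within the data shown here, the only measured step is a modest one elsewhere in the molecule (a 3.7-fold higher number from compound 1 to compound 2 (0.57 log units; beyond the scatter)), between two compounds that already carry the entering group. It shows that compounds with this group can differ beyond the scatter when only the fluorophenyl group changes. Compound 4 is therefore expected to fall within or near their span, with at most a small drop from compound 3 and probably none beyond the scatter. The expected step is small (a 1.7-fold lower number from compound 3 to compound 4 (0.22 log units; within the scatter)). The estimate for compound 4 is 25 nM (expected range 9 nM to 70 nM).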

Compound 4, half-maximal inhibitory concentration: 28.2 nM
For compound 4 the middle estimate is 1.1-fold (0.05 log units) below the measured one; the measured number falls inside the stated range.
By their numbers in this assay, from the lowest: compound 1; then compounds 4, 2 and 3 (each within the scatter of the next).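

In this assay, 3,5-dimethoxyphenyl in place of 3,5-dichlorophenyl on the amine nitrogen in a ring gives a 1.5-fold lower number from compound 3 to compound 4 (0.17 log units; within the scatter), so with 3-fluorophenyl held fixed, the two groups cannot be told apart at this position. With 3,5-dimethoxyphenyl held fixed, the exchange of 4-fluorophenyl for 3-fluorophenyl gives a 1.4-fold lower number from compound 2 to compound 4 (0.14 log units; within the scatter), whereas that of 2-fluorophenyl for 3-fluorophenyl gives a 2.7-fold higher number from compound 1 to compound 4 (0.44 log units; beyond the scatter), so among these three compounds only the 2-fluorophenyl group of compound 1 stands apart. Nothing in the data offers a reason for either result.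

From the compounds shown here alone, the 3,5-dichlorophenyl group appears only with 3-fluorophenyl, so it remains open whether the exchange at the nitrogen would stay this small with 2-fluorophenyl. Also open, going by these compounds, is how an unsubstituted phenyl or a 3,5-dimethylphenyl group would read at that nitrogen.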